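Swapping Ring Substituents on a Weak Orexin Receptor Blocker

The source may report more compounds than this note shows. Statements on the series, on what has been measured and on what is new or still open speak of the compounds shown alone.

Compound 1 `CCN(CC)C(=O)CN(c1cc2c(C)nsc2cc1Cl)S(=O)(=O)c1ccc(OC)c(OC)c1`: 29 nM
Compound 2 `CCN(CC)C(=O)CN(c1cc(Cl)ccc1N(C)C)S(=O)(=O)c1ccc(OC)c(OC)c1`: 4880 nM

For the measured compounds named here, in a functional assay on CHO cells for inhibition of Orexin/Hypocretin receptor type 1 (Homo sapiens), read by FLIPR and calcium flux (a higher number here means a weaker inhibitor, a lower number a stronger inhibitor), compound 1 gives 29 nM while compound 2 gives 4880 nM, the higher of the two numbers; the one measured step is a 170-fold higher number from compound 1 to compound 2 (2.23 log units; beyond the scatter).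

Compound 3 `CCN(CC)C(=O)CN(c1cc(N(C)C)ccc1OC)S(=O)(=O)c1ccc(OC)c(OC)c1` differs from compound 2 by 5-(dimethylamino)-2-methoxyphenyl in place of 5-chloro-2-(dimethylamino)phenyl on a sulfonamide nitrogen. Going by the values given here, no measured step bears on this change: the only step known exchanged a bicyclic group for a single ring, which says nothing about moving the dimethylamino group or trading chlorine for methoxy. The expectation is therefore no step beyond the scatter, a 1.0-fold higher number from compound 2 to compound 3 (0.01 log units; within the scatter), with wide uncertainty. Compound 3 is estimated at 5000 nM, between 1500 nM and 15000 nM.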

Compound 3, half-maximal inhibitory concentration: > 10000 nM
Compound 3 gave a limit, no number; the forecaster's own chance of this, stated with the estimate: 20%; middle value at least 2.0-fold (0.30 log units) away from the limit.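

In this assay compound 3 gives only a limit of the assay, not a number: the limit of > 10000 nM in this assay, at which 1 of the 3 values shown sits. Putting 5-(dimethylamino)-2-methoxyphenyl in place of 5-chloro-2-(dimethylamino)phenyl on the sulfonamide nitrogen gives an at least 2.0-fold higher number from compound 2 to compound 3 (0.31 log units; beyond the scatter), so this new single-ring group does not win back what the two-ring group gave. Measured from that two-ring group, the change is an at least 340-fold higher number from compound 1 to compound 3 (2.53 log units; beyond the scatter).

Chlorine leaves, methoxy enters and the dimethylamino group changes place in one step, so which of these matters stays open. From the compounds shown here alone, whether a single ring carrying fluorine or a methyl group would fare better also stays open.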